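A few compounds are considered here, and "the series" means these few. Any claim that something is new, unique, unknown or untested is made for them only; others in the source may bear on it.

Of the compounds shown here, three with a shared core have been tested in a functional assay on PC-3 cells (Homo sapiens) for cytotoxicity, read by MTT assay, with a stated time of 48 h; a lower number here means a stronger inhibitor, a higher number a weaker inhibitor. Compound 1 `O=C(c1ccccc1)N1N=C(c2cc3ccccc3oc2=O)CC1c1ccccc1` gives 5870 nM in this assay. Compound 2 `O=C(CCl)N1N=C(c2cc3ccccc3oc2=O)CC1c1ccccc1` gives 2980 nM. Compound 3 `CN1CCN(CC(=O)N2N=C(c3cc4ccccc4oc3=O)CC2c2ccccc2)CC1` gives 25800 nM, the highest of the three numbers. The step of a 2.0-fold lower number from compound 1 to compound 2 (0.29 log units; within the scatter) is a small one, while the steps of a 4.4-fold higher number from compound 1 to compound 3 (0.64 log units; beyond the scatter) and an 8.7-fold higher number from compound 2 to compound 3 (0.94 log units; beyond the scatter) set compound 3 apart from both of the others.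

Compound 4 `NC(=O)C1CCN(CC(=O)N2N=C(c3cc4ccccc4oc3=O)CC2c2ccccc2)CC1` has not yet been measured in this assay. It differs from compound 3 in one place: 4-carbamoylpiperidin-1-yl in place of 4-methylpiperazin-1-yl on a saturated chain carbon bound to a carbonyl carbon. Of the measured steps, an 8.7-fold higher number from compound 2 to compound 3 (0.94 log units; beyond the scatter) and a 4.4-fold higher number from compound 1 to compound 3 (0.64 log units; beyond the scatter) bear on this change, since each of them brings in the same chain that compound 3 and compound 4 both carry on the carbonyl carbon. Within the data shown here, no measured step exchanges one six-membered amine ring for another, so there is no direct guide to the swap itself. With the same chain kept in place, compound 4 is expected to stay near compound 3, with no step beyond the scatter. Compound 4 is therefore estimated to give about 20000 nM in this assay, within a range from 6000 nM to 60000 nM. The expected step of a 1.3-fold lower number from compound 3 to compound 4 (0.11 log units; within the scatter) is accordingly a small one.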

Compound 4, half-maximal inhibitory concentration: 8310 nM
For compound 4 the middle estimate is 2.4-fold (0.38 log units) above the measured one, within the range that was stated.
By their numbers in this assay, from the lowest: compounds 2, 1 and 4 (each within the scatter of the next, the first and the last beyond it); then compound 3.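

In this assay, the group on the saturated chain carbon bound to a carbonyl carbon matters even when the amine ring and the chain stay in place: 4-carbamoylpiperidin-1-yl in place of 4-methylpiperazin-1-yl gives a step beyond the scatter (a 3.1-fold lower number from compound 3 to compound 4 (0.49 log units; beyond the scatter)), so the high number of compound 3 does not hold for both six-membered rings shown at this place. The new group still stands apart from chloro at this place (a 2.8-fold higher number from compound 2 to compound 4 (0.45 log units; beyond the scatter)), whereas exchanging the phenyl group for the whole amine chain gives a step within the scatter (a 1.4-fold higher number from compound 1 to compound 4 (0.15 log units; within the scatter)), so the amine chain as such does not set a compound apart from compound 1. No measurement at hand accounts for these differences.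

In the step to compound 4, the ring atom and the carbamoyl group change together, and the compounds shown do not separate them; a plain piperidin-1-yl, a 4-methylpiperidin-1-yl or a morpholin-4-yl at this place would do so. Also open, on these data alone, is how a carboxylic acid in place of the carbamoyl group, or a longer chain carrying the same ring, would read in this assay.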